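The compounds below may be only part of what the source reports. "The series", "measured", "known", "first", "only" and "open" are said of these compounds alone.

Working notes on the series. Compound 1 `C[C@]1(CO)OCC(n2ccc(N)nc2=O)O1`, compound 2 `C[C@]1(CO)OCC(n2cc(F)c(N)nc2=O)O1` and compound 3 `CC1(CO)OC[C@@H](n2ccc(N)nc2=O)O1` have been measured in a functional assay on P388 cells (Mus musculus) for inhibition; on this read-out lower numbers stand for stronger inhibition and higher numbers for weaker inhibition; compound 4 `CC1(CO)OC[C@@H](n2cc(F)c(N)nc2=O)O1` has not. In this assay compound 1 gives only a limit, > 100000 nM. Compound 2 likewise gives only a limit, > 100000 nM. Compound 3 also reaches only a limit, > 100000 nM. From compound 1 to compound 2 the change is fluoro in place of hydrogen on an aromatic carbon; the step that the two limits leave unreadable from compound 1 to compound 2 cannot be sized because of the limit of > 100000 nM in this assay, at which 3 of the 3 values shown sit. The two cores differ as the two compounds have the same atoms and bonds; at least one stereo element is drawn with a configuration in one of them and without one in the other: 2 of 2 stereo elements differ; a stereocentre at a saturated ring carbon is drawn S in compound 1 and without a configuration in compound 3; a stereocentre at a saturated ring carbon is drawn without a configuration in compound 1 and S in compound 3; the step that the two limits leave unreadable from compound 1 to compound 3 is unreadable because the limit of > 100000 nM in this assay, at which 3 of the 3 values shown sit, and because of the fact that one of compounds 1 and 3 is drawn with a defined configuration and the other without, at the place where they differ. The change from compound 3 to compound 4 is fluoro in place of hydrogen on an aromatic carbon, the same change as that from compound 1 to compound 2, here made on the core of compound 3. Compound 3 sits at a limit, > 100000 nM, and the earlier step that the two limits leave unreadable from compound 1 to compound 2 gave no readable movement. Compound 4 is therefore expected to remain at the limit as well, an expected step that the limit leaves unreadable from compound 3 to compound 4. The estimate for compound 4 is 150000 nM, with a range from 50000 nM to 500000 nM.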

Compound 4, half-maximal inhibitory concentration: > 100000 nM
Compound 4: no number, only a limit; the forecaster's own chance of this, stated with the estimate: 90%; the middle value is on the limit's open side.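

Compound 4 gives only a limit in this assay, > 100000 nM. No new step can be read from compound 3 to compound 4 or from compound 2 to compound 4: the limit of > 100000 nM in this assay, at which 4 of the 4 values shown sit.

The compounds shown leave open how strongly any of them inhibits in this assay, and whether fluoro or the drawn configuration makes any difference.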